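The source may report more compounds than this note shows. Statements on the series, on what has been measured and on what is new or still open speak of the compounds shown alone.

Measured compounds and their values:
- compound 1 `COc1ccc(CNC(=O)CC2c3ccccc3N=C(N(C)CCCCCN(C)C)N2c2ccc(-c3ccccc3)cc2)cc1` gives 4460 nM in a functional assay on SK-OV-3 cells (Homo sapiens) for cytotoxicity, read by MTT assay, with a stated time of 48 h; a higher number here means a weaker inhibitor, a lower number a stronger inhibitor
- compound 2 `CN(C)CCN1CCN(C2=Nc3ccccc3C(CC(=O)NCc3ccccc3)N2c2ccc(-c3ccccc3)cc2)CC1` gives 1970 nM in this assay
- compound 3 `CN(C)CCN1CCN(C2=Nc3ccccc3C(CC(=O)NCc3ccc(F)cc3)N2c2ccc(-c3ccccc3)cc2)CC1` gives 3090 nM in this assay

Compound 3 stands second highest of the three numbers in this assay; its nearest neighbour is compound 1 and its furthest compound 2, and both gaps are within the scatter. Within the data shown here, the only step measured between compounds that differ in one place, a 1.6-fold higher number from compound 2 to compound 3 (0.20 log units; within the scatter), is itself within the scatter, so compound 2 and compound 3 are not told apart by this read-out.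

Compound 4 `COc1ccc(CNC(=O)CC2c3ccccc3N=C(N3CCN(CCN(C)C)CC3)N2c2ccc(-c3ccccc3)cc2)cc1` differs from compound 3 in one place: methoxy in place of fluoro on an aromatic carbon. Among the measured compounds shown here, no measured pair shows this exact exchange. Compound 1 carries the same methoxy group on the benzyl part but a different chain on the shared core, so its value and that of compound 3 cannot be separated into the two changes; what the numbers show is that all three measured compounds sit within the scatter of one another. On that basis the step of a 1.0-fold higher number from compound 3 to compound 4 (0.02 log units; within the scatter) is expected to be small, with no clear direction beyond the scatter. Compound 4 is therefore estimated at 3200 nM, with a range from 1300 nM to 8000 nM.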

Compound 4, half-maximal inhibitory concentration: 2470 nM
Beside the measured number, compound 4's estimate is 1.3-fold (0.11 log units) above it; low and high end bracket the measured number.
By their numbers in this assay, from the lowest: compounds 2, 4, 3 and 1 (each within the scatter of the next, the first and the last beyond it).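

At this position, an aromatic carbon para to a large group, methoxy now stands alongside hydrogen and fluoro. In this assay, the exchange for fluoro gives a 1.3-fold lower number from compound 3 to compound 4 (0.10 log units; within the scatter) and the exchange for hydrogen gives a 1.3-fold higher number from compound 2 to compound 4 (0.10 log units; within the scatter), so this read-out tells none of the three apart, and the 4-methoxybenzyl amide fits here without a change that can be read. The new value also supplies a pair with the 4-methoxybenzyl part held fixed, showing that 4-(2-(dimethylamino)ethyl)piperazin-1-yl in place of (5-(dimethylamino)pentyl)(methyl)amino gives a 1.8-fold lower number from compound 1 to compound 4 (0.26 log units; within the scatter), so this exchange on the shared core is not resolved by the read-out either. No measurement is at hand that bears on these results.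

The compounds shown carry only hydrogen, fluoro or methoxy at this aromatic carbon, so it remains open whether a carboxylic acid, an amine or a nitrile there would give a step beyond the scatter. Also open, going by these compounds, is whether a morpholine or a shorter aminoalkyl chain on the shared core would separate from the two groups seen so far.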